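From a succinate ester to an aminopropyl carbamate

The source may hold more compounds than are shown below. What is called first, only, known or untested is meant among the compounds shown, and "the series" means these compounds.

Measured so far:
compound 1 `Cc1cn(C2CC(N=[N+]=[N-])C(COC(=O)OCCCCCCCCO)O2)c(=O)[nH]c1=O` — > 50000 nM
compound 2 `Cc1cn(C2CC(N=[N+]=[N-])C(COC(=O)OCCCCO)O2)c(=O)[nH]c1=O` — > 50000 nM
compound 3 `Cc1cn(C2CC(N=[N+]=[N-])C(COC(=O)CCCC(=O)O)O2)c(=O)[nH]c1=O` — > 50000 nM

In a functional assay on MT4 cells (Homo sapiens) for cytotoxicity (on this read-out higher numbers stand for lower toxicity in this test and lower numbers for higher toxicity in this test), compound 1 gives > 50000 nM, which is a limit of the assay rather than a number. Compound 2 gives > 50000 nM, likewise a limit. Compound 3 gives > 50000 nM, again a limit. All three values sit at the limit of > 50000 nM in this assay, at which 3 of the 3 values shown sit, so compound 3 stands exactly where its two companions stand, and none of the steps among them can be sized: a step that the two limits leave unreadable from compound 1 to compound 2, a step that the two limits leave unreadable from compound 1 to compound 3 and a step that the two limits leave unreadable from compound 2 to compound 3 are all left unreadable by the limits.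

Compound 4 `Cc1cn(C2CC(N=[N+]=[N-])C(COC(=O)NCCCN)O2)c(=O)[nH]c1=O` is the next member. Its difference from compound 3 is (3-aminopropyl)amino in place of 3-carboxypropyl on a carbonyl carbon. Among the compounds with values here, none of the measured steps bears readably on this change, since each of them runs between two limits; the ester-side variations seen so far gave no toxicity within range. Compound 4 is therefore expected to behave like its companions, with the step of a number no higher from compound 3 to compound 4 (the limit leaves the size open) expected to be none beyond the scatter. Compound 4 is estimated at 50000 nM, with a range from 15000 nM to 100000 nM.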

Compound 4, half-maximal cytotoxic concentration: > 50000 nM
Compound 4: no number, only a limit; the forecaster's own chance of this, stated with the estimate: 65%; the middle value lies on the limit itself.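

In this assay compound 4 gives > 50000 nM which is a limit and not a number. Within the data shown here, no step from compound 1, compound 2 or compound 3 to compound 4 can be read: the limit of > 50000 nM in this assay, at which 4 of the 4 values shown sit.

The compounds shown leave open whether any of these changes on a carbonyl carbon alters toxicity in this test.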